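The source may report more compounds than this note shows. Statements on the series, on what has been measured and on what is new or still open speak of the compounds shown alone.

Compound 1 `Cc1ccc(CS/C(=C/c2c(O)cc(O)cc2O)C(=O)c2ccc(Cl)cc2)cc1` has been measured in a functional assay on DU-145 cells (Homo sapiens) for inhibition, read by trypan blue exclusion, with a stated time of 96 h; a lower number here means a stronger inhibitor of growth, a higher number a weaker inhibitor of growth; in this assay compound 1 gives 50000 nM. Compound 2 `O=C(/C(=C\c1c(O)cc(O)cc1O)S(=O)(=O)c1ccccc1Br)c1ccc(Cl)cc1` gives 50000 nM in this assay, so compound 1 stands level with compound 2, its nearest neighbour in the series, the move being no change at the digits printed from compound 1 to compound 2 (within the scatter). Compound 3 `O=C(/C(=C\c1c(O)cc(O)cc1O)SCc1ccc(Cl)cc1)c1ccc(Cl)cc1` reaches only a limit of this assay, > 100000 nM, which is the limit of > 100000 nM in this assay, at which 1 of the 3 values shown sits. The moves to compound 3 are an at least 2.0-fold higher number from compound 1 to compound 3 (0.30 log units; that floor lies within the scatter) and an at least 2.0-fold higher number from compound 2 to compound 3 (0.30 log units; that floor lies within the scatter), each with a floor that sits inside the scatter.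

Compound 4 `Cc1ccc(CS/C(=C/c2ccc(N(C)C)cc2)C(=O)c2ccc(Cl)cc2)cc1` is not yet measured. It differs from compound 1 in 4-(dimethylamino)phenyl in place of 2,4,6-trihydroxyphenyl on a double-bonded chain carbon bound to a double-bonded chain carbon. Every measured step in the series alters the group on the double-bonded chain carbon bound to the carbonyl carbon, or exchanges chloro for methyl on an aromatic carbon; none touches the 2,4,6-trihydroxyphenyl. Among the measured compounds shown here, no measured step therefore bears on this change, and there is no basis for expecting a shift in this assay in either direction beyond the scatter. Compound 4 is estimated at 50000 nM, within a range from 15000 nM to 150000 nM, which means an expected step of no change at the digits printed from compound 1 to compound 4 (within the scatter).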

Compound 4, concentration for 50% growth inhibition: > 100000 nM
Compound 4: no number, only a limit; the forecaster's own chance of this, stated with the estimate: 40%; middle value at least 2.0-fold (0.30 log units) from the limit.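

Among the compounds shown here, this is the first measured change at the aryl group on the double-bonded chain carbon bound to a double-bonded chain carbon; earlier steps left the 2,4,6-trihydroxyphenyl untouched. The exchange for 4-(dimethylamino)phenyl gives an at least 2.0-fold higher number from compound 1 to compound 4 (0.30 log units; that floor lies within the scatter), so the direction points to weaker growth inhibition, but the printed floor does not establish a step beyond the scatter. In this assay compound 4 yields no number, only an assay limit: the limit of > 100000 nM in this assay, at which 2 of the 4 values shown sit.

On these data alone, the true size of the step stays unknown, and the result cannot separate the loss of the three hydroxyl groups from the entry of the dimethylamino group. An unsubstituted phenyl or a 4-hydroxyphenyl at this position would help to separate those two parts of the change.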